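The source may report more compounds than this note shows. Statements on the series, on what has been measured and on what is new or still open speak of the compounds shown alone.

Working notes on the series

Two compounds of the series have a number in an assay on isolated protein for binding affinity to histone acetyltransferase KAT2B (Homo sapiens), read by isothermal titration calorimetry; a higher number here means weaker binding, a lower number tighter binding. Compound 1 `CN1C[C@H](Nc2nc3cc[nH]c3c(=O)n2C)C[C@H](c2ccc(OC(F)(F)F)cc2)C1` gives 140 nM. Compound 2 `C=CCN1C[C@H](Nc2nc3cc[nH]c3c(=O)n2C)C[C@H](c2ccccc2)C1` gives 233 nM. Compound 1 carries the lower of the two numbers, but its gap to compound 2 lies within the scatter of repeated measurements, so the two cannot be told apart on these data, and no ordering is drawn from them.

Compound 3 `COc1ccc([C@H]2C[C@@H](Nc3nc4cc[nH]c4c(=O)n3C)CN(C)C2)cc1` has not yet been measured in this assay. Against compound 1 it shows one change: methyl in place of trifluoromethyl on an oxygen on an aromatic ring. Going by the values given here, no measured pair shows this change, so its effect cannot be read off from any step already in hand; the only anchor is the value of compound 1.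

With nothing to indicate a large effect in either direction, the step from compound 1 to compound 3 is expected to be small, a 1.6-fold higher number from compound 1 to compound 3 (0.20 log units; within the scatter), and most likely to stay within the scatter or edge slightly toward a weaker number. The estimate for compound 3 in this assay is therefore 220 nM, with a range from 90 nM to 550 nM.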

Compound 3, dissociation constant: 106 nM
For compound 3 the middle estimate is 2.1-fold (0.32 log units) above the measured one, and the stated range covers the measured number.
By their numbers in this assay, from the lowest: compounds 3, 1 and 2 (each within the scatter of the next, the first and the last beyond it).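

Going by these compounds alone, the step of a 1.3-fold lower number from compound 1 to compound 3 (0.12 log units; within the scatter) in this assay is the first measured change at this place, and it leaves the two compounds indistinguishable. On an oxygen on an aromatic ring, trifluoromethyl and methyl therefore read alike in this assay, so removing the three fluorine atoms while keeping the oxygen has no effect that can be resolved here, and the place accepts both groups without a measurable loss of binding. No measured information is available to explain why the two groups read alike.

Within the data shown here, this single step covers only two groups on the oxygen, so it cannot show whether the place stays equally permissive for a longer chain such as ethoxy or for a hydroxy group, which has no carbon on that oxygen. It also leaves open whether the oxygen itself is needed, a question that chlorine or an amine in place of the whole trifluoromethoxy or methoxy group would address, and whether a carboxylic acid there would be accepted as readily.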